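Replacing an aryl cap on the piperidine with a hydroxyalkyl chain

The source may report more compounds than this note shows. Statements on the series, on what has been measured and on what is new or still open speak of the compounds shown alone.

Compound 1 `O=C(c1ccccc1)N1CCC(NS(=O)(=O)c2cc(S(=O)(=O)c3ccccc3)ccc2C(F)(F)F)CC1`: 70 nM
Compound 2 `O=C(c1ccc(Cl)cc1)N1CCC(NS(=O)(=O)c2cc(S(=O)(=O)c3ccccc3)ccc2C(F)(F)F)CC1`: 300 nM
Compound 3 `O=C(O)c1ccc(S(=O)(=O)N2CCC(NS(=O)(=O)c3cc(S(=O)(=O)c4ccccc4)ccc3C(F)(F)F)CC2)cc1`: 20 nM

In an assay on isolated protein for displacement of a labelled ligand from secreted frizzled-related protein 1 (Homo sapiens), read by fluorescence polarization, with a stated time of 30 min (on this read-out lower numbers stand for stronger inhibition and higher numbers for weaker inhibition), compound 2 gives the highest number of the three, so it is the weakest binder shown. Compound 4 `CC(C)(O)CCN1CCC(NS(=O)(=O)c2cc(S(=O)(=O)c3ccccc3)ccc2C(F)(F)F)CC1` differs from it in one place: 3-hydroxy-3-methylbutyl in place of (4-chlorophenyl)carbonyl on an amine nitrogen in a ring. Within the data shown here, two measured steps touch the same amine nitrogen. The change a 4.3-fold higher number from compound 1 to compound 2 (0.63 log units; beyond the scatter) shows that adding chloro to the aryl cap weakens binding, while a 15-fold lower number from compound 2 to compound 3 (1.18 log units; beyond the scatter) shows a large gain on moving to a sulfonyl-linked carboxyphenyl. Neither step tests a chain without a ring, so the direction for compound 4 is uncertain; a small step, a 1.5-fold lower number from compound 2 to compound 4 (0.18 log units; within the scatter), is expected. Compound 4 is therefore estimated at 200 nM, within 50 nM to 1000 nM.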

Compound 4, half-maximal inhibitory concentration: 200 nM
Compound 4: middle estimate and measured number agree at the digits printed, and the stated range covers the measured number.
By their numbers in this assay, from the lowest: compound 3; then compound 1; then compounds 4 and 2 (each within the scatter of the next).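

A cap on this amine nitrogen need not contain a ring to reach this level of binding: the chain in compound 4 lies within the scatter of the chlorinated cap, with a 1.5-fold lower number from compound 2 to compound 4 (0.18 log units; within the scatter) as the step. The same chain falls short of the other two caps, with a 2.9-fold higher number from compound 1 to compound 4 (0.46 log units; beyond the scatter) and a 10-fold higher number from compound 3 to compound 4 (1.00 log units; beyond the scatter) as the steps. No measured evidence accounts for these differences.

The compounds shown leave open whether the hydroxyl matters, which a plain alkyl chain would test. They also leave open whether a carboxylic acid at the end of a chain could match compound 3.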